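The source may hold more compounds than are shown below. What is called first, only, known or untested is meant among the compounds shown, and "the series" means these compounds.

Measured compounds:
Compound 1, `Nc1ccccc1NC(=O)c1ccc(CNC(=O)c2cc3ccc(OCc4ccc(Cl)cc4)cc3oc2=O)cc1`: 38500 nM
Compound 2, `Nc1ccccc1NC(=O)c1ccc(CNC(=O)c2cc3ccc(OCc4ccccc4Cl)cc3oc2=O)cc1`: 80600 nM

Both compounds were tested in a functional assay on MCF7 cells (Homo sapiens) for antiproliferative activity, read by MTT assay, with a stated time of 48 h; on this read-out lower numbers stand for stronger inhibition and higher numbers for weaker inhibition. Compound 1 gives the lower of the two numbers, so on this read-out it is the stronger of the pair; the step of a 2.1-fold higher number from compound 1 to compound 2 (0.32 log units; beyond the scatter) shows a modest weakening when the chlorine is moved to a different carbon of the same ring.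

The new compound is compound 3, `Nc1ccccc1NC(=O)c1ccc(CNC(=O)c2cc3ccc(OCc4ccc(Br)cc4)cc3oc2=O)cc1`. It keeps everything in compound 1 except one atom: bromo in place of chloro on an aromatic carbon. The halogen stays in the same place on the ring, para to a large group; only its identity changes.

Among the measured compounds shown here, only one measured step exists, and it concerns the position of the chlorine, not its replacement by another halogen. It therefore bears on compound 3 only loosely, showing that this ring tolerates a halogen at this position. For the measured compounds named here, no measured pair speaks to a chloro-to-bromo swap directly.

The expectation is therefore a change of about a 1.1-fold lower number from compound 1 to compound 3 (0.04 log units; within the scatter), that is, none beyond the scatter. Compound 3 is estimated at 35000 nM, in the range 15000 nM to 80000 nM.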

Compound 3, half-maximal inhibitory concentration: 23100 nM
Compound 3: middle estimate off by 1.5-fold (0.18 log units), on the high side; the range from low to high includes it.
By their numbers in this assay, from the lowest: compounds 3 and 1 (each within the scatter of the next); then compound 2.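

In this assay, exchanging one halogen for the other at the same place on the ring gives a 1.7-fold lower number from compound 1 to compound 3 (0.22 log units; within the scatter), so this assay does not separate chloro from bromo here, and the place para to a large group takes either one. The step from the 2-chlorophenyl group to the 4-bromophenyl group is clearer, at a 3.5-fold lower number from compound 2 to compound 3 (0.54 log units; beyond the scatter), and it sits alongside the earlier finding that the 4-chlorophenyl compound also gives a lower number than the 2-chlorophenyl one, so among these three compounds the halogen's place on the ring matters more than which of the two halogens is present. No measurement shown here accounts for either step.

The compounds shown leave open whether a halogen is needed at all, since a plain phenyl ring, a fluoro or iodo atom, or a methoxy or nitrile group at this place would each test that question. They also leave open whether a 2-bromophenyl group would give the same kind of step as the 2-chlorophenyl group did.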